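Cyclopropane dicarboxamides: a 3-methylphenyl anilide

A few compounds are considered here, and "the series" means these few. Any claim that something is new, unique, unknown or untested is made for them only; others in the source may bear on it.

Measured compounds:
compound 1 `Cc1nc2c(F)cc(-c3nc(Nc4ccc(NC(=O)C5(C(=O)Nc6ccc(F)cc6)CC5)cc4)ncc3F)cc2n1C(C)C` gives 191 nM in a functional assay on HeLa cells (Homo sapiens) for antiproliferative activity, read by CCK-8 assay, with a stated time of 72 h; on this read-out higher numbers stand for weaker inhibition and lower numbers for stronger inhibition
compound 2 `Cc1ccc(NC(=O)C2(C(=O)Nc3ccc(Nc4ncc(F)c(-c5cc(F)c6nc(C)n(C(C)C)c6c5)n4)cc3)CC2)cc1` gives 71.5 nM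
compound 3 `Cc1nc2c(F)cc(-c3nc(Nc4ccc(NC(=O)C5(C(=O)Nc6ccc(Br)cc6)CC5)cc4)ncc3F)cc2n1C(C)C` gives 597 nM

Compound 3 has the highest number of the three in this assay, a weaker inhibitor than compound 1 by a 3.1-fold higher number from compound 1 to compound 3 (0.49 log units; beyond the scatter) and than compound 2 by an 8.3-fold higher number from compound 2 to compound 3 (0.92 log units; beyond the scatter). Compound 4 `Cc1cccc(NC(=O)C2(C(=O)Nc3ccc(Nc4ncc(F)c(-c5cc(F)c6nc(C)n(C(C)C)c6c5)n4)cc3)CC2)c1` is not yet measured; it differs from compound 3 by 3-methylphenyl in place of 4-bromophenyl on an amide-type nitrogen. The step from compound 2 to compound 3, bromo in place of methyl, bears on this change, as does the step of a 2.7-fold lower number from compound 1 to compound 2 (0.43 log units; beyond the scatter); both favour methyl over a halogen. Returning to methyl, though at a different position, is therefore expected to lower the number. The estimated step is a 4.6-fold lower number from compound 3 to compound 4 (0.66 log units; beyond the scatter), and compound 4 is expected at 130 nM, between 45 nM and 400 nM.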

Compound 4, half-maximal inhibitory concentration: 179 nM
Estimate against measurement, compound 4: 1.4-fold (0.14 log units) below; measured number inside the range.
By their numbers in this assay, from the lowest: compound 2; then compounds 4 and 1 (each within the scatter of the next); then compound 3.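

In this assay, exchanging 4-methylphenyl for 3-methylphenyl on the amide-type nitrogen gives (a 2.5-fold higher number from compound 2 to compound 4 (0.40 log units; beyond the scatter)), so where the methyl sits on this ring matters, not only its presence. The 3-methylphenyl group keeps an edge over 4-bromophenyl (a 3.3-fold lower number from compound 3 to compound 4 (0.52 log units; beyond the scatter)) but none over 4-fluorophenyl (a 1.1-fold lower number from compound 1 to compound 4 (0.03 log units; within the scatter)), so compound 4 goes against any general preference for methyl over halogen here. No measurement offered here explains these differences. As far as these compounds go, whether a methoxy or trifluoromethyl group on this ring would rank with the methyl compounds or with the halogen compounds remains open.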